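A few compounds are considered here, and "the series" means these few. Any claim that something is new, unique, unknown or untested is made for them only; others in the source may bear on it.

Measured compounds:
compound 1 `CC(=O)Nc1ccc2c(c1)/C(=N\O)C(c1c[nH]c3ccc(NC(C)=O)cc13)=N2`: 17900 nM
compound 2 `c1ccc(CO/N=C2/C(c3c[nH]c4ccccc34)=Nc3ccccc32)cc1`: 15400 nM
compound 3 `Cc1ccc(CO/N=C2/C(c3c[nH]c4ccc(Br)cc34)=Nc3ccc(Br)cc32)cc1`: 31200 nM

In a functional assay on MGC-803 cells (Homo sapiens) for cytotoxicity, read by MTT assay, with a stated time of 2 days (on this read-out lower numbers stand for stronger inhibition and higher numbers for weaker inhibition), compound 3 gives the highest of the three numbers. Against compound 1 that gap lies within the usual scatter, so no order between the two can be claimed; against compound 2 the gap lies just beyond it. Compound 4 `FC(F)(F)c1ccc(CO/N=C2/C(c3c[nH]c4ccc(Br)cc34)=Nc3ccc(Br)cc32)cc1` differs from compound 3 by a single change, (trifluoromethyl in place of methyl on an aromatic carbon). For the measured compounds named here, no pair of measured compounds shows this kind of change, so nothing in the data sets the size or direction of the step; the three measured values all sit within a narrow band. The estimate for compound 4 in this assay is therefore a step of a 1.1-fold lower number from compound 3 to compound 4 (0.05 log units; within the scatter), with compound 4 expected at 28000 nM, between 10000 nM and 80000 nM.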

Compound 4, half-maximal inhibitory concentration: 11100 nM
Compound 4: the middle estimate sits 2.5-fold (0.40 log units) above what was measured; the measured number falls inside the stated range.
By their numbers in this assay, from the lowest: compounds 4, 2, 1 and 3 (each within the scatter of the next, the first and the last beyond it).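

Moving from 4-methylbenzyl to 4-(trifluoromethyl)benzyl in this assay gives a 2.8-fold lower number from compound 3 to compound 4 (0.45 log units; beyond the scatter) and is the first single-place step in this set. It shows that the number responds to the group on this aromatic carbon, para to a large group, although the step is modest. No measurement here accounts for the step.

Still open, on these data alone, is whether a methoxy group, a nitrile or an amine at this place would move the number the same way. As far as these compounds go, it is also open whether the step would persist on the core without the two bromines.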